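Methyl in Place of Bromo: What to Expect for Compound 4

The source may hold more compounds than are shown below. What is called first, only, known or untested is meant among the compounds shown, and "the series" means these compounds.

Measured so far:
compound 1 `O=C1/C(=C/c2cccc(Br)c2)Cc2ccccc21`: 32400 nM
compound 2 `O=C1/C(=C/c2ccc(Br)cc2)Cc2ccccc21`: 284000 nM
compound 3 `Cc1cccc(/C=C2\Cc3ccccc3C2=O)c1`: 41300 nM

In a functional assay on CCRF-CEM cells (Homo sapiens) for inhibition (a lower number here means a stronger inhibitor, a higher number a weaker inhibitor), compound 1 gives 32400 nM, compound 2 gives 284000 nM and compound 3 gives 41300 nM. Compound 2 has the highest number of the three, and its distance to compound 3 and to compound 1 lies beyond the scatter. Compounds 1 and 2 are built from the same atoms joined differently; the difference between the two cores is not broken down here.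

From compound 1 to compound 3 the change is methyl in place of bromo on an aromatic carbon and it gives a 1.3-fold higher number from compound 1 to compound 3 (0.11 log units; within the scatter) in this assay.

Compound 4 `Cc1ccc(/C=C2\Cc3ccccc3C2=O)cc1` has not yet been measured. It differs from compound 2 by methyl in place of bromo on an aromatic carbon. This is the same kind of change as that from compound 1 to compound 3, but the place is not identical: in compound 1 the exchanged group sits meta to a large group, in compound 2 para to a large group.

The step from compound 2 to compound 4 is expected to be a 1.2-fold higher number from compound 2 to compound 4 (0.09 log units; within the scatter), because the same kind of change gave a 1.3-fold higher number from compound 1 to compound 3 (0.11 log units; within the scatter). Compound 4 is therefore estimated to give about 350000 nM in this assay, most likely between 150000 nM and 900000 nM.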

Compound 4, half-maximal inhibitory concentration: 67100 nM
Compound 4: the middle estimate sits 5.2-fold (0.72 log units) above what was measured, and the stated range ends above it.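

With methyl in place of bromo, this assay shows a 4.2-fold lower number from compound 2 to compound 4 (0.63 log units; beyond the scatter). Set beside the earlier step, this change did not carry over at a constant size from the core of compound 1 to the core of compound 2: the same change on two cores in this assay, a 1.3-fold higher number (0.11 log units; within the scatter) from compound 1 to compound 3 and a 4.2-fold lower number (0.63 log units; beyond the scatter) from compound 2 to compound 4, 5.4-fold (0.73 log units) apart, beyond the scatter of two such steps

Among the compounds shown here, this shows that, in this series, the step seen on one core was no reliable guide to the step on the other, but with only two pairs it does not show why they differ, nor what the same change would do on any further core.

The compounds shown leave open how other groups would behave at these two places, since only bromo and methyl appear there, and a methoxy group, an amine or a carboxylic acid might follow either step or neither. Equally open, on these data alone, is whether a longer chain such as ethyl would track methyl on either core.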